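Iodine Added on the Way from Compound 3 to Compound 4

The compounds below may be only part of what the source reports. "The series", "measured", "known", "first", "only" and "open" are said of these compounds alone.

Of the compounds shown here, three have so far been tested in a functional assay on KB cells (Homo sapiens) for cytotoxicity; a lower number here means that less compound is needed, a higher number that more compound is needed for the effect. Compound 1 `CCC[C@@H](OC(C)=O)C1=C(Br)/C(=C/Br)OC1=O` gives 2.1 ug/mL, and compound 2 `CCC[C@@H](OC(C)=O)C1=C(Br)C(=C(Br)Br)OC1=O` gives 0.5 ug/mL. Compound 3 `CCC[C@@H](OC(C)=O)C1=C(Br)[C@@](C)(OC)OC1=O` gives 10.7 ug/mL, the highest of the three numbers, so more of compound 3 is needed for the effect than of either other compound, and both gaps lie beyond the usual scatter. Compound 4 `CCC[C@@H](OC(C)=O)C1=C(Br)[C@@](CI)(OC)OC1=O` has not yet been measured. It differs from compound 3 by iodo in place of hydrogen on a saturated chain carbon bound to a saturated ring carbon. Within the data shown here, no measured pair shows this change, so its size is unknown. A modest step to a lower number is expected, a 1.8-fold lower number from compound 3 to compound 4 (0.25 log units; within the scatter) in this assay, though a result within the scatter would not surprise. The estimate for compound 4 is 6 ug/mL, with a range from 2 ug/mL to 20 ug/mL.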

Compound 4, concentration for half-maximal effect: 4.1 ug/mL
For compound 4 the middle estimate is 1.5-fold (0.17 log units) above the measured one; the range from low to high includes it.
By their numbers in this assay, from the lowest: compound 2; then compounds 1 and 4 (each within the scatter of the next); then compound 3.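

This is the first pair shown that differs in only one place: going from methyl to iodomethyl brings a 2.6-fold lower number from compound 3 to compound 4 (0.42 log units; beyond the scatter) in this assay and so shows that this position responds to a change. Adding iodine on this saturated chain carbon lowers the amount of compound needed for the effect rather than raising it. Nothing shown explains why the number falls. The compounds shown leave open whether iodine itself matters, or whether a chloromethyl or an aminomethyl group in the same place would give a similar step.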